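Changing the Amide Group of Compound 1

A few compounds are considered here, and "the series" means these few. Any claim that something is new, unique, unknown or untested is made for them only; others in the source may bear on it.

Going by the values given here, in a physicochemical assay for lipophilicity, read by HPLC (a lower number here means a more polar compound, a higher number a more lipophilic compound), compound 1 `Cc1ccsc1C(=CCCN(C)C(CCO)C(=O)NCc1ccc(F)cc1)c1sccc1C` gives 5.87, the lower of the two numbers so far, and compound 2 `Cc1ccsc1C(=CCCN(C)C(CO)C(=O)NCc1ccc(F)cc1)c1sccc1C` gives 6.45. Compound 3 `Cc1ccsc1C(=CCCN(C)C(CCO)C(=O)NC(C)c1ccccc1)c1sccc1C` has 1-phenylethyl in place of 4-fluorobenzyl on an amide-type nitrogen. Among the compounds with values here, the one measured step, a number 0.58 log units higher from compound 1 to compound 2 (beyond the scatter), involves hydroxymethyl on a saturated chain carbon, so it shows only the size one small change can reach. Within the data shown here, no measured step covers this change. The expected result, a small rise, is a number 0.13 log units higher from compound 1 to compound 3 (within the scatter). For compound 3 the estimate is 6, with an expected range from 5.6 to 6.5.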

Compound 3, partition coefficient: 6.1
Beside the measured number, compound 3's estimate is 0.10 log units below it; the range from low to high includes it.
By their numbers in this assay, from the lowest: compounds 1 and 3 (each within the scatter of the next); then compound 2.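

Placing 1-phenylethyl in place of 4-fluorobenzyl on the amide-type nitrogen gives, in this assay, a number 0.23 log units higher from compound 1 to compound 3 (within the scatter), so the two compounds cannot be told apart here. At this position, then, one group of 8 heavy atoms with a six-membered aromatic ring can stand in for the other without a step beyond the scatter. No measured evidence bears on why the two read alike.

A plain benzyl group on this nitrogen could separate the loss of fluorine from the added carbon. Going by these compounds, how a group carrying an amine or a carboxylic acid would read at this position also stays open.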